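Swapping the halogenated aryl amine in a diterpenoid lactone series

The source may hold more compounds than are shown below. What is called first, only, known or untested is meant among the compounds shown, and "the series" means these compounds.

Compound 1 `C=C1[C@@H](OC(C)=O)C[C@@H]2[C@](C)(COC=O)[C@H](OC(C)=O)CC[C@@]2(C)[C@@H]1C[C@@H](Nc1ccc(Br)cc1)C1=CCOC1=O` was tested in a functional assay on KB cells (Homo sapiens) for cytotoxicity, read by sulforhodamine B assay (on this read-out lower numbers stand for stronger inhibition and higher numbers for weaker inhibition), and gives 24000 nM. Compound 2 `C=C1[C@@H](OC(C)=O)C[C@@H]2[C@](C)(CO[Si](C)(C)C(C)(C)C)[C@H](OC(C)=O)CC[C@@]2(C)[C@@H]1C[C@@H](Nc1ccc(F)cc1)C1=CCOC1=O` in this assay gives 5090 nM. Of these two numbers, compound 1 has the higher one, and the gap between compound 2 and compound 1 lies beyond the usual scatter. Compound 2 differs from compound 1 in more than one place, so no single structural cause can be read from that gap. Compound 3 `C=C1[C@@H](OC(C)=O)C[C@@H]2[C@](C)(COC=O)[C@H](OC(C)=O)CC[C@@]2(C)[C@@H]1C[C@@H](Nc1ccccc1F)C1=CCOC1=O` carries one change relative to compound 1: 2-fluorophenyl in place of 4-bromophenyl on an amine nitrogen. Among the compounds with values here, no measured pair shows this change on its own, so the expectation rests on compound 1 alone. The step of a 1.6-fold lower number from compound 1 to compound 3 (0.20 log units; within the scatter) is expected to be small, tending toward a somewhat lower number but not clearly beyond the scatter. For compound 3, the estimated value in this assay is 15000 nM, with a plausible range from 5000 nM to 45000 nM.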

Compound 3, half-maximal inhibitory concentration: 29000 nM
Estimate against measurement, compound 3: 1.9-fold (0.29 log units) below; measured number inside the range.
By their numbers in this assay, from the lowest: compound 2; then compounds 1 and 3 (each within the scatter of the next).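

Within this assay putting 2-fluorophenyl in place of 4-bromophenyl on an amine nitrogen gives a 1.2-fold higher number from compound 1 to compound 3 (0.08 log units; within the scatter) and so leaves the two compounds indistinguishable. This pair isolates the aryl group on that nitrogen, which the comparison of compound 1 with compound 2 could not do, and shows that this particular swap of halogen and ring position has no visible effect on the read-out. Nothing available explains this result.

From the compounds shown here alone, since the halogen and its ring position both differ in this step, the contribution of each alone remains unknown. Going by these compounds, it also remains open whether plain phenyl, 4-methoxyphenyl or a saturated cyclohexyl group on the same nitrogen would stay within the scatter of compound 1.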